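The compounds below may be only part of what the source reports. "The series", "measured", "known", "first", "only" and "open" are said of these compounds alone.

Measured in a toxicity assay on Vero cells (Chlorocebus sabaeus) for cytotoxicity; a lower number here means a stronger inhibitor, a higher number a weaker inhibitor:
- compound 1 `O=c1cc([Se]c2ccccc2)n(COCCO)c(=O)[nH]1`: > 100000 nM, a limit
- compound 2 `Cc1c([Se]c2ccccc2)n(COCCO)c(=O)[nH]c1=O`: > 100000 nM, a limit
- compound 3 `O=c1[nH]c(=O)n(COCCO)c([Se]c2ccccc2)c1F`: 25700 nM

Not yet measured: compound 4 `O=c1[nH]c(=O)n(COCCO)c([Se]c2ccccc2)c1Br`.

Going by the values given here, compound 3 is the only one with a true number. The other two values sit at the limit of > 100000 nM in this assay, at which 2 of the 3 values shown sit.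

Compound 4 carries bromo in place of fluoro on an aromatic carbon.

The closest evidence is an at least 3.8-fold lower number from compound 1 to compound 3 (0.59 log units; beyond the scatter) and an at least 3.8-fold lower number from compound 2 to compound 3 (0.59 log units; beyond the scatter), both steps that introduce the fluoro group. By contrast, a step that the two limits leave unreadable from compound 1 to compound 2 gives no guidance. Among the compounds with values here, no measured step exchanges one halogen for another, so the read-across is weak.

The expected step is a 1.6-fold higher number from compound 3 to compound 4 (0.19 log units; within the scatter), probably not beyond the scatter, with any drift expected towards a higher number. For compound 4 the estimated value is 40000 nM, with an expected range of 12000 nM to 100000 nM.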

Compound 4, half-maximal inhibitory concentration: 8200 nM
Compound 4: middle estimate off by 4.9-fold (0.69 log units), on the high side; the measured number lies below the stated range.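

In this assay, the choice of halogen at this carbon matters, and bromo goes further than fluoro: a 3.1-fold lower number from compound 3 to compound 4 (0.50 log units; beyond the scatter). Lowering of the number is therefore not confined to fluoro, as bromo also gives an at least 12-fold lower number from compound 1 to compound 4 (1.08 log units; beyond the scatter) and an at least 12-fold lower number from compound 2 to compound 4 (1.08 log units; beyond the scatter). Both of these sizes are open-ended, and the hydrogen and methyl compounds give only a limit: the limit of > 100000 nM in this assay, at which 2 of the 4 values shown sit.

As far as these compounds go, the halogen comparison rests on two compounds, so how chloro or iodo would fall at this carbon remains open. Whether a nitrile or an amine here would also lower the number is equally unknown.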